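Propylamino at the position where butylsulfanyl once stood

The source may hold more compounds than are shown below. What is called first, only, known or untested is meant among the compounds shown, and "the series" means these compounds.

For the measured compounds named here, compound 2 `Nc1ncnc2c1nc(O)n2Cc1ccccc1` gives 10 uM in a functional assay (spleen, spleen) for activation, with Mus musculus as the target (a higher number here means that more compound is needed for the effect, a lower number that less compound is needed), the highest of the two numbers known, while compound 1 `CCCCSc1nc(N)c2nc(O)n(Cc3ccccc3)c2n1` gives 0.01 uM. Compound 3 `CCCNc1nc(N)c2nc(O)n(Cc3ccccc3)c2n1` carries propylamino in place of hydrogen on an aromatic carbon, on the aromatic carbon between two ring nitrogen atoms. Going by the values given here, the one step that bears on this is a 1000-fold higher number from compound 1 to compound 2 (3.00 log units; beyond the scatter), which shows how much a group at this carbon can matter. A large step downward is therefore expected for compound 3, a 330-fold lower number from compound 2 to compound 3 (2.52 log units; beyond the scatter). Compound 3 is estimated at 0.03 uM, within a range of 0.003 uM to 0.3 uM.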

Compound 3, minimum effective concentration: 0.1 uM
Compound 3: middle estimate off by 3.3-fold (0.52 log units), on the low side, within the range that was stated.
By their numbers in this assay, from the lowest: compound 1; then compound 3; then compound 2.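

In this assay, propylamino on this aromatic carbon also brings a large change (a 100-fold lower number from compound 2 to compound 3 (2.00 log units; beyond the scatter)), so the gain seen earlier does not belong to butylsulfanyl alone. The two groups are still not interchangeable here, as propylamino in place of butylsulfanyl gives a smaller but real shift (a 10-fold higher number from compound 1 to compound 3 (1.00 log units; beyond the scatter)). Still open, going by these compounds, is how butylamino or butoxy would compare on the shared core, which would separate the length of the chain from the atom that links it. No evidence on the cause of these differences is available.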